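Working notes on a stilbene-linked series, step to compound 4

The source may report more compounds than this note shows. Statements on the series, on what has been measured and on what is new or still open speak of the compounds shown alone.

Measured so far in a functional assay on DLD-1 cells (Homo sapiens), read by microscopy and crystal violet staining, with a stated time of 20 h, tested at 10 ug/mL; on this read-out lower numbers stand for less inhibition and higher numbers for more inhibition at the one concentration tested (going by the name of the read-out):
compound 1 `O=C1NC(=S)S/C1=C\c1cc(Br)ccc1OCc1ccccc1Br` gives 95%
compound 2 `O=C1NC(=S)S/C1=C\C=C\c1ccccc1OCc1ccncc1` gives 62%
compound 3 `O=C1NC(=O)/C(=C/C=C/c2ccccc2OCc2ccccc2Br)S1` gives 50%

Compound 2 stands second highest of the three numbers. The nearest value, that of compound 3, lies below it by a margin beyond the scatter; the furthest, that of compound 1, lies well above it, again beyond the scatter. Among the compounds with values here, no pair of these three differs in only one place, so no single-point step can be read from the measured compounds, and the spread among them shows only that the group on the ether oxygen and the length of the linker both go along with different numbers.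

The next compound, compound 4 `COc1ccccc1/C=C/C=C1\SC(=S)NC1=O`, keeps the core and the three-carbon linker of compound 2 and differs by hydrogen in place of pyridin-4-yl on a saturated chain carbon bound to an oxygen on an aromatic ring. The expected change is a number 12 percentage points lower from compound 2 to compound 4 (beyond the scatter), a downward move of modest size that may not exceed the scatter, since the higher values here go with a larger group on that oxygen and no value is at hand for a bare methoxy. Compound 4 is expected to give 50%, with a range from 25% to 75%.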

Compound 4, a percentage reported as inhibition, at one concentration (the size of the read-out at that concentration, not a potency): 69%
Compound 4: middle estimate off by 19 percentage points, on the low side; the measured number falls inside the stated range.
By their numbers in this assay, from the lowest: compound 3; then compounds 2 and 4 (each within the scatter of the next); then compound 1.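

In this assay, within the data shown here, the first step that differs in one place, from (pyridin-4-yl)methoxy to methoxy, reads a number 7 percentage points higher from compound 2 to compound 4 (within the scatter) and lies within the scatter. On a saturated chain carbon bound to an oxygen on an aromatic ring, hydrogen in place of pyridin-4-yl therefore leaves this pair indistinguishable on this read-out, although the group that leaves has 6 heavy atoms and the one that enters has none. No measured evidence on this result is at hand.

The compounds shown leave open whether a carboxylic acid, an amine or a longer chain at this place would also stay within the scatter of compound 2. They also leave open whether the same change reads alike on the core of compound 3 or with the linker of compound 1.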